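The compounds below may be only part of what the source reports. "The series", "measured", "known", "first", "only" and "open" are said of these compounds alone.

Among the three compounds measured in an assay on cells for displacement of a labelled ligand from metabotropic glutamate receptor 2 (Homo sapiens), read by scintillation counting, with a stated time of 60 min (a lower number here means a stronger inhibitor, a higher number a weaker inhibitor), compound 3 `FC(F)(F)c1c(-c2ccc(OC3CCOCC3)c(Cl)c2)ccn2c(CC3CC3)nnc12` gives 5.25 nM, the lowest of the three numbers. Compound 1 `Clc1cc(-c2ccn3c(CC4CC4)nnc3c2Cl)ccc1NC1CC1` gives 6.76 nM, which lies within the scatter of compound 3, so no order between the two can be claimed. Compound 2 `Clc1cc(-c2ccn3c(CC4CC4)nnc3c2Cl)ccc1OC1CCOCC1` gives 22.9 nM, and the step of a 4.4-fold lower number from compound 2 to compound 3 (0.64 log units; beyond the scatter) is beyond the scatter.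

Compound 4 `O[C@H]1CC[C@H](Oc2ccc(-c3ccn4c(CC5CC5)nnc4c3C(F)(F)F)cc2Cl)CC1` differs from compound 3 in one place: 4-hydroxycyclohexyl in place of oxan-4-yl on an oxygen on an aromatic ring. Of the measured steps, only a 3.4-fold higher number from compound 1 to compound 2 (0.53 log units; beyond the scatter) touches the same oxygen-bearing position, and it was modest; the step of a 4.4-fold lower number from compound 2 to compound 3 (0.64 log units; beyond the scatter) concerns a different position and bears on this change only by showing how the shared core behaves. The change from compound 3 to compound 4 keeps a six-membered saturated ring on that oxygen and swaps one oxygen for a hydroxyl-bearing carbon, so the expected step of a 1.2-fold higher number from compound 3 to compound 4 (0.09 log units; within the scatter) in this assay is small, with no clear direction beyond the scatter. Compound 4 is therefore estimated at 6.5 nM, within a range of 2.5 nM to 17 nM.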

Compound 4, inhibition constant: 1.91 nM
Compound 4: middle estimate off by 3.4-fold (0.53 log units), on the high side; measured number outside the range, below it.
By their numbers in this assay, from the lowest: compound 4; then compounds 3 and 1 (each within the scatter of the next); then compound 2.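

In this assay the exchange of oxan-4-yl for 4-hydroxycyclohexyl on the oxygen gives a 2.7-fold lower number from compound 3 to compound 4 (0.44 log units; beyond the scatter) and so shows that this position still responds when the six-membered ring is kept and trifluoromethyl is present on the shared core. The earlier step at this site, a 3.4-fold higher number from compound 1 to compound 2 (0.53 log units; beyond the scatter) changed the atom attached to the aromatic carbon as well as the group, whereas here the oxygen stays and only the ring changes, gaining a hydrogen-bond donor and losing its hetero atom. No measurement is available to explain this step.

The compounds shown do not separate the effect of the hydroxyl from that of the all-carbon ring, which a plain cyclohexyl group on the same oxygen would address. They also leave open how the other stereoisomer of 4-hydroxycyclohexyl, or an amine on that ring, would read.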